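Compound 3 to compound 4: pyridin-2-yl for 3-methylphenyl

The source may hold more compounds than are shown below. What is called first, only, known or untested is meant among the compounds shown, and "the series" means these compounds.

Compound 1 `COc1ccc([C@H]2CC(=O)N(C(C)=O)C2)cc1OC1CCCC1` gives > 10000 nM as a limit
Compound 2 `COc1ccc([C@H]2CC(=O)N(c3ccccc3N)C2)cc1OC1CCCC1` gives > 10000 nM as a limit
Compound 3 `COc1ccc([C@H]2CC(=O)N(c3cccc(C)c3)C2)cc1OC1CCCC1` gives > 10000 nM as a limit

All three results come from a functional assay on HEK293 cells (Homo sapiens) for cytotoxicity (on this read-out lower numbers stand for higher toxicity in this test and higher numbers for lower toxicity in this test), and none is an exact number. In this assay compound 3 gives > 10000 nM as a limit, so it cannot be ranked against the other two. The whole set so far shows the limit of > 10000 nM in this assay, at which 3 of the 3 values shown sit, and nothing else.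

Compound 4 `COc1ccc([C@H]2CC(=O)N(c3ccccn3)C2)cc1OC1CCCC1` has pyridin-2-yl in place of 3-methylphenyl on an amide-type nitrogen in a ring.

Three measured steps exchange groups at this same nitrogen (a step that the two limits leave unreadable from compound 1 to compound 2) (a step that the two limits leave unreadable from compound 1 to compound 3) (a step that the two limits leave unreadable from compound 2 to compound 3). Both ends of each step are limits, so their sizes cannot be read. With acetyl, 2-aminophenyl and 3-methylphenyl, no result has come off the limit. No step beyond the scatter is therefore expected in this assay in either direction, though a step hidden behind these limits cannot be ruled out. The expected step is small (a number no higher from compound 3 to compound 4 (the limit leaves the size open)). For compound 4 the estimate is 10000 nM with an expected range from 5000 nM to 20000 nM and the assay will most likely report only a limit again.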

Compound 4, half-maximal cytotoxic concentration: > 10000 nM
Compound 4 gave a limit, no number (the forecaster's own chance of this, stated with the estimate: 85%); the middle value sits exactly at the limit.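

In this assay compound 4 gives > 10000 nM, which is a limit and not a number. Going by these compounds alone, compound 1, compound 2 and compound 3 also gave limits, so no step from any of them to compound 4 can be read. The compounds shown leave open whether exchanging the group on the amide-type nitrogen changes the result in this assay, as all four share one limit: the limit of > 10000 nM in this assay, at which 4 of the 4 values shown sit.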